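The compounds below may be only part of what the source reports. "The series", "measured", "known", "first", "only" and "open" are said of these compounds alone.

Measured compounds:
compound 1 `COc1cccc(-c2n[nH]cc2N2CCNCC2)c1` — 2100 nM
compound 2 `COc1ccc(-c2n[nH]cc2N2CCNCC2)cc1` — > 10000 nM

Of the compounds shown here, two with a shared core have been measured in an assay on isolated protein for binding affinity to 5-hydroxytryptamine receptor 3A (Homo sapiens); on this read-out lower numbers stand for stronger inhibition and higher numbers for weaker inhibition. In this assay compound 1 gives 2100 nM. For compound 2 the value of > 10000 nM is a limit of the assay and not a number. So compound 1 stands as the only compound with a true number here, the other result being (the limit of > 10000 nM in this assay, at which 1 of the 2 values shown sits).

The compound that remains to be measured is compound 3 `Clc1cccc(-c2n[nH]cc2N2CCNCC2)c1`. It differs from compound 1 in one place: chloro in place of methoxy on an aromatic carbon. The group sits on an aromatic carbon of a six-membered aromatic ring of carbon only, meta to a large group.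

Going by the values given here, no measured pair that differs only in this way is available, so the size of the step cannot be read from the data. The step from compound 1 to compound 3 is expected to be a 1.4-fold lower number from compound 1 to compound 3 (0.15 log units; within the scatter), that is, close to no change beyond the usual scatter. On that basis compound 3 is estimated to give 1500 nM in this assay, with a likely range from 300 nM to 7000 nM.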

Compound 3, inhibition constant: 806 nM
Compound 3: middle estimate off by 1.9-fold (0.27 log units), on the high side; the range from low to high includes it.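

In this assay, putting chloro in place of methoxy on the aromatic carbon meta to a large group gives a 2.6-fold lower number from compound 1 to compound 3 (0.42 log units; beyond the scatter), a modest step that lies beyond the usual scatter. Going by these compounds alone, until now the series held only one true number, so nothing showed whether this place responds to a change of group at all; this pair shows that it does, and that losing the methoxy, with the hydrogen-bond acceptor counted for it, does not cost binding here. Within the data shown here, nothing measured so far says why the number falls in this pair.

As far as these compounds go, a single step cannot show how far this place can be pushed, so it remains open whether a smaller or very different group there, such as fluoro, an amine or a carboxylic acid, would lower the number further, leave it unchanged or raise it. Compound 2 offers no readable step for comparison, as its result is a limit and not a number: the limit of > 10000 nM in this assay, at which 1 of the 3 values shown sits.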